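A Cyano Substituent on the Sulfonate Ring

The compounds below may be only part of what the source reports. "The series", "measured", "known", "first", "only" and "open" are said of these compounds alone.

Of the compounds shown here, three built around a shared core have been tested in an assay (strain Sprague-Dawley) for inhibition of Amine oxidase [flavin-containing] B (Rattus norvegicus), read by spectrophotometry, with a stated time of 5 min, tested at 10 uM; on this read-out lower numbers stand for less inhibition and higher numbers for more inhibition at the one concentration tested (going by the name of the read-out). Compound 1 `CNC(=O)/C=C1/COc2cc(OS(=O)(=O)c3ccccc3)ccc21` gives 0%. Compound 2 `CNC(=O)/C=C1/COc2cc(OS(=O)(=O)c3ccc(Cl)cc3)ccc21` gives 6%, and compound 3 `CNC(=O)/C=C1/COc2c1ccc(OS(=O)(=O)c1ccccc1)c2C` gives 5%. On these numbers compound 3 sits nearest to compound 2 and furthest from compound 1, yet all three values lie within the usual scatter of one another, so none of them can be told apart from the rest.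

Compound 4 `CNC(=O)/C=C1/COc2c1ccc(OS(=O)(=O)c1ccc(C#N)cc1)c2C` has not been measured. It differs from compound 3 in one place: cyano in place of hydrogen on an aromatic carbon Seen one bond further out, the phenyl of the sulfonate becomes 4-cyanophenyl.

Among the compounds with values here, two measured steps bear on this. Placing chloro on the same ring, a number 6 percentage points higher from compound 1 to compound 2 (within the scatter). Placing methyl on the core, a number 5 percentage points higher from compound 1 to compound 3 (within the scatter). Neither change moved the read-out beyond the scatter, and nothing measured here shows a cyano group doing otherwise. In this assay compound 4 is therefore expected to give about 7%, in a range from 0% to 20%. The step this expectation implies, a number 2 percentage points higher from compound 3 to compound 4 (within the scatter), is expected to stay within the scatter.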

Compound 4, a percentage reported as inhibition, at one concentration (the size of the read-out at that concentration, not a potency): 6%
Compound 4: middle estimate off by 1 percentage points, on the high side, and the stated range covers the measured number.
By their numbers in this assay, from the lowest: compounds 1, 3, 2 and 4 (each within the scatter of the next).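

In this assay the change from phenyl to 4-cyanophenyl on the sulfonate, with cyano para to a large group, leaves the number within the scatter (a number 1 percentage points higher from compound 3 to compound 4 (within the scatter)). The earlier steps shown here each started from compound 1 and changed one place at a time, whereas this step changes the phenyl of the sulfonate in a compound that already carries the methyl on the core, and that combination also stays within the scatter. Nothing measured here explains this result or ties it to any property of the cyano group.

From the compounds shown here alone, whether an amine or a carboxylic acid on that same aromatic carbon would move the number beyond the scatter remains open, as does whether a longer chain in place of the methyl on the core would do so. Also open, going by these compounds, is what cyano does on the phenyl of the sulfonate when the methyl is absent from the core, and how these compounds would compare at a concentration other than the single one tested here.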